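Dimethylamino in place of acetyl on the shared core

This account rests on a few compounds, and the source may have more. Where it says the series, first, only, none or still open, it means among the compounds named here.

Compound 1 `COc1cc(C)cc(-c2c(-c3ccnc(-c4ccc(C(C)=O)cc4)c3)cnn2CC#N)c1` and compound 2 `COc1cc(C)cc(-c2nn(CC#N)cc2-c2ccnc(-c3ccc(N(C)C)cc3)c2)c1` have both been run in a functional assay on UO-31 cells (Homo sapiens) for cytotoxicity, read by sulforhodamine B assay, with a stated time of 48 h, tested at 0.001 uM; a higher number here means a weaker effect of the compound at the concentration tested, a lower number a stronger effect. In this assay compound 1 gives 88%, and compound 2 gives 90%; the two numbers lie within the usual scatter of each other, so at the concentration tested neither compound shows more than a marginal effect. Within the data shown here, no pair of measured compounds differs in a single place, so no single step is yet known. Compound 3 `COc1cc(C)cc(-c2c(-c3ccnc(-c4ccc(N(C)C)cc4)c3)cnn2CC#N)c1` is the next compound to be measured in this assay. Relative to compound 1 it carries dimethylamino in place of acetyl on an aromatic carbon. Compound 2, which also bears a dimethylamino group, gives 90% in this assay. The step of a number 2 percentage points higher from compound 1 to compound 3 (within the scatter) is therefore expected to stay within the scatter, with no direction favoured. For compound 3 the expected value is 90%, within a range of 80% to 100%.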

Compound 3, a percentage reported as activity, at one concentration (the size of the read-out at that concentration, not a potency): 83%
Compound 3: middle estimate off by 7 percentage points, on the high side, within the range that was stated.
By their numbers in this assay, from the lowest: compounds 3, 1 and 2 (each within the scatter of the next).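

Among these compounds, the first single-place step is a number 5 percentage points lower from compound 1 to compound 3 (within the scatter) in this assay, for dimethylamino in place of acetyl on an aromatic carbon, para to a large group. At this position, then, 4-acetylphenyl and 4-(dimethylamino)phenyl cannot be told apart at the one concentration tested, although the exchange replaces a carbonyl-bearing group with an amine of the same heavy-atom count. Nothing at hand gives a reason for this result.

Still open, going by these compounds, is whether a carboxylic acid or a morpholine at this position would carry the read-out beyond the scatter. Also open, on these data alone, is whether the acetyl and dimethylamino compounds would separate at higher concentrations, where the effect on the cells may be larger than the marginal one seen here.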